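Benzoxaborole amides against ovarian cancer cells: fluoro to ethynyl

The compounds below may be only part of what the source reports. "The series", "measured", "known", "first", "only" and "open" are said of these compounds alone.

Measured compounds:
Compound 1, `CCNC(=O)CCc1cccc2c1B(O)OC2`, > 100000 nM
Compound 2, `CC(C)(C)NC(=O)CCc1cccc2c1B(O)OC2`, > 100000 nM
Compound 3, `O=C(CCc1cccc2c1B(O)OC2)Nc1ccc(F)cc1`, 720 nM

Of the compounds shown here, three sharing one core have been tested in a functional assay on SK-OV-3 cells (Homo sapiens) for antiproliferative activity, read by MTT assay, with a stated time of 72 h; on this read-out higher numbers stand for weaker inhibition and lower numbers for stronger inhibition. Compound 1 carries an ethyl group on the amide nitrogen; in this assay compound 1 reaches only the limit of > 100000 nM, not a number. Compound 2 carries a tert-butyl group there and likewise stops at the limit of > 100000 nM. For the measured compounds named here, compound 3, with a 4-fluorophenyl group on the same nitrogen, is the only compound with a real number, 720 nM. The steps to it are both large: an at least 130-fold lower number from compound 1 to compound 3 (2.14 log units; beyond the scatter) and an at least 130-fold lower number from compound 2 to compound 3 (2.14 log units; beyond the scatter). The step that the two limits leave unreadable from compound 1 to compound 2 stays hidden, since both values sit at the limit of > 100000 nM in this assay, at which 2 of the 3 values shown sit.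

Compound 4, `C#Cc1ccc(NC(=O)CCc2cccc3c2B(O)OC3)cc1`, remains to be measured. It keeps the aryl amide of compound 3 and changes one substituent: ethynyl in place of fluoro on an aromatic carbon. No measured step touches this kind of change; the only shown steps swap an alkyl for an aryl group, which compound 4 retains. The expectation is therefore a step of a 1.2-fold lower number from compound 3 to compound 4 (0.08 log units; within the scatter), within the usual scatter. Compound 4 is estimated at 600 nM, from 200 nM to 2000 nM.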

Compound 4, half-maximal inhibitory concentration: 6300 nM
For compound 4 the middle estimate is 11-fold (1.02 log units) below the measured one; the whole stated range lies below it.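

Every step measured earlier changed the group on the amide nitrogen, so those compounds said nothing about how much the substituent on the aromatic ring of the aryl amide matters. With that amide kept and only the substituent para to a large group changed, ethynyl in place of fluoro gives an 8.8-fold higher number from compound 3 to compound 4 (0.94 log units; beyond the scatter) in this assay, which shows that activity here depends on what this aromatic carbon carries, even though compound 4 still gives a measurable value of 6300 nM. Nothing measured here bears on why this change weakens the effect on the cells.

A single pair cannot show whether fluoro is especially favourable at this carbon or ethynyl especially unfavourable, so the compounds shown leave open how an amine, a methoxy group or a carboxylic acid at the same place would compare with compound 3. They also leave open whether a longer chain linking the shared core to the amide would change the value of compound 3 or compound 4, and whether the effect of the ring substituent would then stay the same.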